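The source may report more compounds than this note shows. Statements on the series, on what has been measured and on what is new or still open speak of the compounds shown alone.

Measured in a functional assay on the whole organism for antagonist activity, with Mus musculus as the target; a lower number here means that less compound is needed, a higher number that more compound is needed for the effect:
- Compound 1 `CC(=O)N(C)C(C)C#CCn1ccnc1`: > 100 mg/kg
- Compound 2 `COC(=O)N(C)CC#CCn1ccnc1`: > 100 mg/kg
- Compound 3 `COC(=O)N(C)C(C)C#CCN1CCCC1`: > 100 mg/kg

Compound 3 gives > 100 mg/kg, which is a limit of the assay and not a number. The other two compounds offer no number either, and the whole set reads (the limit of > 100 mg/kg in this assay, at which 3 of the 3 values shown sit).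

Compound 4 `COC(=O)N(C)C(C)C#CCn1ccnc1` has 1H-imidazol-1-yl in place of pyrrolidin-1-yl on a saturated chain carbon bound to a triple-bonded carbon.

Compound 1 also carries 1H-imidazol-1-yl and gives > 100 mg/kg, again a limit. Compound 2 carries it too and gives > 100 mg/kg, also a limit. No step beyond the scatter is expected in this assay, in either direction. Compound 4 is expected near 120 mg/kg, with an estimated range of 50 mg/kg to 300 mg/kg.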

Compound 4, dose for half-maximal effect: > 100 mg/kg
Compound 4: a limit, no number; the forecaster's own chance of this, stated with the estimate: 65%; the middle value does not contradict the limit.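

Compound 4 gives > 100 mg/kg as a limit and not a number. Going by these compounds alone, no step from compound 1, compound 2 or compound 3 to compound 4 can be read, as all four sit at one limit: the limit of > 100 mg/kg in this assay, at which 4 of the 4 values shown sit. On these data alone, how these compounds compare in this assay stays open.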